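Swapping one fluoro for chloro in compound 2

The source may report more compounds than this note shows. Statements on the series, on what has been measured and on what is new or still open speak of the compounds shown alone.

Measured in a functional assay on SK-OV-3 cells (Homo sapiens); on this read-out higher numbers stand for weaker inhibition of growth and lower numbers for stronger inhibition of growth:
- compound 1 `O=S(=O)(/C=C/c1ccc(Cl)c(Cl)c1)Cc1ccc(Nc2ncnc3ccccc23)cc1`: 22000 nM
- compound 2 `O=S(=O)(/C=C/c1ccc(F)cc1F)Cc1ccc(Nc2ncnc3ccccc23)cc1`: 69000 nM

Of these two, compound 2 has the higher number and so the weaker growth inhibition. Compound 3 `O=S(=O)(/C=C/c1ccc(F)cc1Cl)Cc1ccc(Nc2ncnc3ccccc23)cc1` differs from it by chloro in place of fluoro on an aromatic carbon.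

Going by the values given here, the only measured step is a 3.1-fold higher number from compound 1 to compound 2 (0.50 log units; beyond the scatter). It is modest and swaps a whole 2,4-difluorophenyl for 3,4-dichlorophenyl, so it gives only a weak guide to a single swap. A smaller move in the opposite direction is expected in this assay. The expected change is a 1.6-fold lower number from compound 2 to compound 3 (0.22 log units; within the scatter). Compound 3 is expected at 42000 nM, within an estimated range of 18000 nM to 90000 nM.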

Compound 3, concentration for 50% growth inhibition: 44000 nM
Estimate against measurement, compound 3: 1.0-fold (0.02 log units) below; measured number inside the range.
By their numbers in this assay, from the lowest: compounds 1, 3 and 2 (each within the scatter of the next, the first and the last beyond it).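

On this aromatic carbon, ortho to a large group, chloro in place of fluoro gives a 1.6-fold lower number from compound 2 to compound 3 (0.20 log units; within the scatter) in this assay and so this single swap cannot be told apart from repeat-measurement noise. Replacing 3,4-dichlorophenyl with 2-chloro-4-fluorophenyl gives a 2.0-fold higher number from compound 1 to compound 3 (0.30 log units; within the scatter) and this larger change on the same ring also stays inside that noise. Nothing available explains these numbers.

As far as these compounds go, whether a bromo or methyl group on this carbon would give a clearer separation remains open. So does the outcome with a methoxy group or an amine there.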